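The source may report more compounds than this note shows. Statements on the series, on what has been measured and on what is new or still open speak of the compounds shown alone.

In an ADME assay on HeLa cells (Homo sapiens) for cytotoxicity, read by MTT assay, with a stated time of 2 days (a higher number here means that more compound is tolerated, a lower number that less compound is tolerated), compound 1 (`CCOC(=O)c1cc2ccc(Oc3ccncc3)cc2s1`) gives 43900 nM and compound 2 (`CNC(=O)c1cc(Oc2ccc3cc(C(=O)OC(C)C)n(C)c3c2)ccn1`) gives 46100 nM. Compound 3 (`CNC(=O)c1cc(Oc2ccc3c(C)c(C(=O)OC(C)C)[nH]c3c2)ccn1`) gives 8400 nM, the lowest of the three numbers and beyond the scatter from both others. Compound 4 (`CNC(=O)c1cc(Oc2ccc3c(C)c(C(=O)OC(C)C)n(C)c3c2)ccn1`) follows from compound 3 with methyl in place of hydrogen on an aromatic nitrogen. Within the data shown here, no measured pair isolates this change. Among the measured compounds shown here, the only guide is compound 2, which also bears methyl on that nitrogen but lacks the other methyl group, at 46100 nM. A modest rise in this assay is therefore expected, slightly beyond the scatter, and the expected step is a 2.4-fold higher number from compound 3 to compound 4 (0.38 log units; beyond the scatter). For compound 4 the estimated value is 20000 nM, with an expected range of 8000 nM to 50000 nM.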

Compound 4, half-maximal cytotoxic concentration: 8500 nM
Compound 4: middle estimate off by 2.4-fold (0.37 log units), on the high side; the range from low to high includes it.
By their numbers in this assay, from the lowest: compounds 3 and 4 (each within the scatter of the next); then compounds 1 and 2 (each within the scatter of the next).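

Methyl in place of hydrogen on the aromatic nitrogen gives a 1.0-fold higher number from compound 3 to compound 4 (0.01 log units; within the scatter) in this assay and so does not separate the two compounds at this position. With methyl held on that nitrogen, methyl in place of hydrogen on an aromatic carbon gives a 5.4-fold lower number from compound 2 to compound 4 (0.73 log units; beyond the scatter) and accounts for the difference in this pair. No evidence on the cause of either step is available.
As far as these compounds go, it remains open whether a longer chain on that nitrogen would also leave the number within the scatter. An ethyl group on the aromatic carbon is equally untested by these compounds.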